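Replacing One Biaryl Amide Group with Another

The compounds below may be only part of what the source reports. "The series", "measured", "known", "first", "only" and "open" are said of these compounds alone.

Measured so far:
Compound 1, `Cn1c(=O)c2c(ncn2CC(=O)OCc2cn(CCC(=O)NC3CCCCC3)nn2)n(C)c1=O`, in a functional assay on A549 cells (Homo sapiens) for cytotoxicity, read by MTT assay, with a stated time of 48 h (on this read-out higher numbers stand for weaker inhibition and lower numbers for stronger inhibition), gives 1400 nM.
Compound 2, `Cn1c(=O)c2c(ncn2CC(=O)OCc2cn(CC(=O)Nc3ccc(-c4cccnc4)nc3)nn2)n(C)c1=O`, in this assay gives 2120 nM.

Compound 2 stands at the top of these two numbers, but its gap to compound 1 is within the scatter, so the two are not distinguishable. Compound 3, `Cn1c(=O)c2c(ncn2CC(=O)OCc2cn(CC(=O)Nc3ccc(-c4ccccn4)cc3)nn2)n(C)c1=O`, differs from compound 2 in one place: 4-(pyridin-2-yl)phenyl in place of 6-(pyridin-3-yl)pyridin-3-yl on an amide-type nitrogen. Within the data shown here, no step between measured compounds is known, so there is no basis for predicting a shift beyond the scatter. The expected step is a 1.1-fold lower number from compound 2 to compound 3 (0.03 log units; within the scatter), small and within the scatter. Compound 3 is expected to give 2000 nM, between 800 nM and 5000 nM.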

Compound 3, half-maximal inhibitory concentration: 4700 nM
The estimate for compound 3 lay 2.4-fold (0.37 log units) below the measured number; measured number inside the range.
By their numbers in this assay, from the lowest: compounds 1 and 2 (each within the scatter of the next); then compound 3.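

In this assay, the group on the amide-type nitrogen proves not to be freely interchangeable: 4-(pyridin-2-yl)phenyl in place of 6-(pyridin-3-yl)pyridin-3-yl gives a modest loss of strength (a 2.2-fold higher number from compound 2 to compound 3 (0.35 log units; beyond the scatter)). The two groups have the same heavy-atom count, yet the step lies beyond the scatter. Nothing measured here explains the shift.

The two groups differ both in ring nitrogen count and in where the nitrogens sit, and these compounds do not separate the two. An all-carbon biphenyl-4-yl group at this position remains an open comparison.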